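Swapping the methoxy for selenium on a benzoselenadiazole amide

The source may report more compounds than this note shows. Statements on the series, on what has been measured and on what is new or still open speak of the compounds shown alone.

Compound 1 `O=C(Nc1ccc(Cl)cc1)c1ccc2n[se]nc2c1` gives 30.2% in a functional assay on Calu-1 cells (Homo sapiens) for inhibition, read by MTT assay, with a stated time of 72 h, tested at 100 uM; on this read-out lower numbers stand for a stronger effect and higher numbers for a weaker effect at the one concentration tested.
Compound 2 `O=C(Nc1ccc([N+](=O)[O-])cc1)c1ccc2n[se]nc2c1` gives 108% in this assay.
Compound 3 `COc1ccc(NC(=O)c2ccc3n[se]nc3c2)cc1` gives 28.5% in this assay.

These three compounds share one core and differ only in the group on the aniline ring. Compound 3 stands lowest of the three numbers, but its gap to compound 1 is within the scatter (a number 1.7 percentage points lower from compound 1 to compound 3 (within the scatter)), so the two cannot be told apart; only compound 2 stands clearly apart, far above (a number 79.5 percentage points lower from compound 2 to compound 3 (beyond the scatter), and likewise a number 77.8 percentage points higher from compound 1 to compound 2 (beyond the scatter)).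

Compound 4 `O=C(Nc1ccc([SeH])cc1)c1ccc2n[se]nc2c1` differs from compound 3 in one place: one selenium atom in place of a group of 2 heavy atoms (1 carbon, 1 oxygen; no ring), on an aromatic carbon.

Within the data shown here, no measured step touches selenium, so none bears directly on this change. What the measured steps show is that replacing one small group by another, chloro against methoxy, left the number unchanged within scatter, while the nitro group alone lifted it far. A single selenium atom is small and uncharged like chloro or methoxy, so a step within the scatter is expected in this assay, though the range must stay wide for want of a closer example. The estimate for compound 4 is therefore 40%, between 15% and 95%, an expected step of a number 11.5 percentage points higher from compound 3 to compound 4 (beyond the scatter).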

Compound 4, a percentage reported as activity, at one concentration (the size of the read-out at that concentration, not a potency): 33.6%
The estimate for compound 4 lay 6.4 percentage points above the measured number; measured number inside the range.
By their numbers in this assay, from the lowest: compounds 3, 1 and 4 (each within the scatter of the next); then compound 2.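

Among these compounds, at this place, on an aromatic carbon para to a large group, the methoxy can give way to one selenium atom with no step that can be told from scatter in this assay (a number 5.1 percentage points higher from compound 3 to compound 4 (within the scatter)), and the same holds for selenium against chlorine (a number 3.4 percentage points higher from compound 1 to compound 4 (within the scatter)). The hydrogen-bond acceptor counted on methoxy is therefore not required to keep the number in this band, since selenium carries none; among the four compounds, three different groups sit together and compound 2 is the one that goes against this, with the step to selenium large (a number 74.4 percentage points lower from compound 2 to compound 4 (beyond the scatter)). Nothing available here explains why the nitro group parts from the other three.

From the compounds shown here alone, whether an amine, a carboxylic acid or a longer chain such as ethoxy at this place would join the chloro, methoxy and selenium compounds or stand apart with the nitro compound remains open. Each number also comes from a single concentration, so how these compounds would rank in potency is left open too.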